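The source may hold more compounds than are shown below. What is called first, only, known or untested is meant among the compounds shown, and "the series" means these compounds.

Compound 2 `O=C1C(Nc2ccc(CO)cc2)=CC(=O)c2ncncc21` is the weakest-looking member of a small set of three anilino-substituted analogues sharing one core. In a functional assay on MIA PaCa-2 cells (Homo sapiens) for cytotoxicity, read by MTT assay, with a stated time of 72 h (a higher number here means a weaker inhibitor, a lower number a stronger inhibitor), compound 2 gives 3500 nM, the highest of the three numbers. The nearest neighbour is compound 3 `COc1ccc(NC2=CC(=O)c3ncncc3C2=O)cc1OC`, which in this assay gives 1800 nM, a gap that lies within the scatter, so the two cannot be ordered. Among the measured compounds shown here, the furthest is compound 1 `O=C1C(Nc2ccc(OC(F)(F)F)cc2)=CC(=O)c2ncncc21`, which in this assay gives 1400 nM; the single one-point step recorded, a 2.5-fold higher number from compound 1 to compound 2 (0.40 log units; beyond the scatter), is modest but beyond the scatter.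

Compound 4 `CCOC(=O)c1ccc(NC2=CC(=O)c3ncncc3C2=O)cc1` alters the same position once more: ethoxycarbonyl in place of hydroxymethyl on an aromatic carbon. For the measured compounds named here, only the step from compound 1 to compound 2 bears on it, since it is the only recorded change at this carbon, and it was modest. Going by the values given here, no analogue carries an ethoxycarbonyl or any related ester, so the direction for compound 4 cannot be read from precedent. All three numbers sit inside a narrow band, and a step of similar, modest size in either direction, or none beyond the scatter, is the reasonable expectation in this assay. Compound 4 is therefore estimated at 2500 nM, with a range from 900 nM to 7000 nM, meaning an expected step of a 1.4-fold lower number from compound 2 to compound 4 (0.15 log units; within the scatter).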

Compound 4, half-maximal inhibitory concentration: 5500 nM
Estimate against measurement, compound 4: 2.2-fold (0.34 log units) below; low and high end bracket the measured number.
By their numbers in this assay, from the lowest: compounds 1, 3, 2 and 4 (each within the scatter of the next, the first and the last beyond it).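

At this position, ethoxycarbonyl in place of hydroxymethyl gives a 1.6-fold higher number from compound 2 to compound 4 (0.20 log units; within the scatter) in this assay, so the larger group, which has no hydrogen-bond donor, cannot be separated from the smaller one, which has one. Set against trifluoromethoxy, the same ester gives a 3.9-fold higher number from compound 1 to compound 4 (0.59 log units; beyond the scatter), and with a 2.5-fold higher number from compound 1 to compound 2 (0.40 log units; beyond the scatter) this shows that hydroxymethyl and ethoxycarbonyl both stand apart from trifluoromethoxy beyond the scatter, though not from each other. No measurement is at hand that would explain how these groups fall.

The compounds shown leave open how a carboxylic acid, a primary amide or a methyl ester at this carbon would compare with ethoxycarbonyl, and whether a single chlorine or a trifluoromethyl group would stay close to trifluoromethoxy or fall with the other two. They also leave open whether the same small steps would appear on another cell line, as every number here comes from this assay.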